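Diethylcarbamoyl in place of (isopropylamino)methyl on the benzimidazole-bearing core

The source may hold more compounds than are shown below. What is called first, only, known or untested is meant among the compounds shown, and "the series" means these compounds.

Measured so far:
compound 1, `Cc1cccc2[nH]c(-c3n[nH]c4ncc(-c5cncc6ccccc56)cc34)nc12`, 1720 nM
compound 2, `CC(C)NCc1cccc2[nH]c(-c3n[nH]c4ncc(-c5cncc6ccccc56)cc34)nc12`, 140 nM

In a functional assay on A-375 cells (Homo sapiens) for antiproliferative activity (a higher number here means a weaker inhibitor, a lower number a stronger inhibitor), compound 2 gives the lowest of the two numbers; its nearest neighbour is compound 1, and a 12-fold lower number from compound 1 to compound 2 (1.09 log units; beyond the scatter). Compound 3, `CCN(CC)C(=O)c1cccc2[nH]c(-c3n[nH]c4ncc(-c5cncc6ccccc56)cc34)nc12`, differs from compound 2 by diethylcarbamoyl in place of (isopropylamino)methyl on an aromatic carbon. Among the measured compounds shown here, the only step that bears on this change is a 12-fold lower number from compound 1 to compound 2 (1.09 log units; beyond the scatter), which shows that what sits at this position moves the number a great deal. For the measured compounds named here, since the group that enters is not the one that gave compound 2 its low number, compound 3 is expected to lose ground, with a 5.7-fold higher number from compound 2 to compound 3 (0.76 log units; beyond the scatter). Compound 3 is therefore estimated at 800 nM, within 250 nM to 2500 nM.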

Compound 3, half-maximal inhibitory concentration: 71 nM
For compound 3 the middle estimate is 11-fold (1.05 log units) above the measured one; the measured number lies below the stated range.
By their numbers in this assay, from the lowest: compounds 3 and 2 (each within the scatter of the next); then compound 1.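

In this assay, the low number at this position is not tied to (isopropylamino)methyl: diethylcarbamoyl, with no hydrogen-bond donor, serves as well (a 2.0-fold lower number from compound 2 to compound 3 (0.29 log units; within the scatter)). The gain over methyl thus holds for two different groups, one an amine and one an amide (a 24-fold lower number from compound 1 to compound 3 (1.38 log units; beyond the scatter)). Nothing at hand explains why these two groups stand level. The compounds shown leave open whether the amide's ethyl chains matter, as a dimethylamide or a primary amide would test. They also leave open whether a carboxylic acid or a cyclic amine would fare the same.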